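Tert-butyl for trifluoromethyl: a step not yet measured

The compounds below may be only part of what the source reports. "The series", "measured", "known", "first", "only" and "open" are said of these compounds alone.

For the measured compounds named here, compound 1 `CC(C(=O)NCc1cc(C(F)(F)F)nn1-c1ccc(C(F)(F)F)cc1)c1ccc2c(c1)CCC2` gives 51.3 nM in an assay on CHO-K1 cells for antagonist activity at transient receptor potential cation channel subfamily V member 1 (Homo sapiens), read by FLIPR (a lower number here means a stronger inhibitor, a higher number a weaker inhibitor), the highest of the two numbers so far. Its nearest neighbour is compound 2 `CC(C(=O)NCc1cc(C(F)(F)F)nn1-c1ccc(F)c(F)c1)c1ccc2c(c1)CCC2`, which in this assay gives 30.5 nM; the step of a 1.7-fold lower number from compound 1 to compound 2 (0.23 log units; within the scatter) is within the scatter and concerns 3,4-difluorophenyl in place of 4-(trifluoromethyl)phenyl on an aromatic nitrogen, a different place from the change considered here.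

Compound 3 `CC(C(=O)NCc1cc(C(C)(C)C)nn1-c1ccc(C(F)(F)F)cc1)c1ccc2c(c1)CCC2` differs from compound 1 by tert-butyl in place of trifluoromethyl on an aromatic carbon. Going by the values given here, no measured step touches this position, so the two numbers give no direction for it, and the only measured step is itself within the scatter. No step beyond the scatter is therefore expected in this assay, though the uncertainty is wider than for a change already sampled.

Compound 3 is expected to give 50 nM (range 15 nM to 170 nM) in this assay. The expected step of a 1.0-fold lower number from compound 1 to compound 3 (0.01 log units; within the scatter) is thus essentially flat.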

Compound 3, inhibition constant: 62.4 nM
Compound 3: middle estimate off by 1.2-fold (0.10 log units), on the low side; the range from low to high includes it.
By their numbers in this assay, from the lowest: compounds 2, 1 and 3 (each within the scatter of the next, the first and the last beyond it).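

In this assay, the position on the aromatic carbon of the five-membered aromatic ring now has its first measured step: tert-butyl in place of trifluoromethyl gives a 1.2-fold higher number from compound 1 to compound 3 (0.09 log units; within the scatter). With 4-(trifluoromethyl)phenyl held constant, the fluorine atoms of the trifluoromethyl group are therefore not needed to keep the number within the scatter of compound 1, and the all-carbon tert-butyl serves equally well here. No available evidence bears on why the two groups read alike.

On these data alone, whether this position accepts groups of another kind, such as an amine, a carboxylic acid or a longer chain, remains open. Also open, as far as these compounds go, is whether tert-butyl and trifluoromethyl still read alike with 3,4-difluorophenyl in place of 4-(trifluoromethyl)phenyl on an aromatic nitrogen.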